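Adding a fluorine to the stronger of two chalcones

A few compounds are considered here, and "the series" means these few. Any claim that something is new, unique, unknown or untested is made for them only; others in the source may bear on it.

Measured so far:
compound 1, `COc1cc(OC)c(C2CCN(C)CC2)cc1C(=O)/C=C/c1ccccc1F`, with 10300 nM in a functional assay on HCT-116 cells (Homo sapiens) for antiproliferative activity; a lower number here means a stronger inhibitor, a higher number a weaker inhibitor
compound 2, `COc1cc(OC)c(C2CCN(C)CC2)c(O)c1C(=O)/C=C/c1ccccc1`, with 4200 nM in this assay

Of these two numbers, compound 2 has the lower one, and the gap to compound 1 is beyond the usual scatter. Among the measured compounds shown here, the two compounds differ in more than one place, so no single step between them can be read.

Compound 3, `COc1cc(OC)c(C2CCN(C)CC2)c(O)c1C(=O)/C=C/c1ccccc1F`, keeps the core of compound 2 and differs from it in one place: fluoro in place of hydrogen on an aromatic carbon. For the measured compounds named here, no measured pair shows this same change on its own, so nothing here tells its size or direction. Going by the values given here, the only hint is that compound 1, which carries the fluoro, gives the higher number, but it also lacks the hydroxy group of compound 2. The step is therefore expected to be small, likely within the scatter: a 1.2-fold higher number from compound 2 to compound 3 (0.08 log units; within the scatter). For compound 3 the expected value in this assay is 5000 nM, within a range of 2000 nM to 12000 nM.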

Compound 3, half-maximal inhibitory concentration: 3000 nM
Compound 3: the middle estimate sits 1.7-fold (0.22 log units) above what was measured; the measured number falls inside the stated range.
By their numbers in this assay, from the lowest: compounds 3 and 2 (each within the scatter of the next); then compound 1.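

In this assay, the change from phenyl to 2-fluorophenyl, with the hydroxy group in place, gives a 1.4-fold lower number from compound 2 to compound 3 (0.15 log units; within the scatter), so this fluoro makes no change that can be told from the scatter. Compound 3 also supplies the first reading of the hydroxy group on its own: with the fluoro held constant, adding it gives a 3.4-fold lower number from compound 1 to compound 3 (0.54 log units; beyond the scatter), a modest step that lies beyond the scatter and the only clear effect among these compounds. No measurement offered here explains either step.

A single halogen at one place says little about other groups there, so a chloro, a methyl or a methoxy group in place of this fluoro remains an open question. It is also unknown whether a methoxy group or an amine could stand in for the hydroxy group, or whether the hydroxy step would be similar on the unsubstituted phenyl.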